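Trimethoxyphenyl to dimethoxyphenyl on the enone pyrazole series

The compounds below may be only part of what the source reports. "The series", "measured", "known", "first", "only" and "open" are said of these compounds alone.

Measured so far:
compound 1 `COc1ccc(-c2cc(/C=C/C(=O)c3ccc(N)cc3)[nH]n2)cc1` — -23%
compound 2 `COc1cc(-c2cc(/C=C/C(=O)c3ccc(N)cc3)[nH]n2)cc(OC)c1OC` — -45%
compound 3 `COc1cc(-c2cc(/C=C/C(=O)c3ccc(F)c(F)c3)[nH]n2)cc(OC)c1OC` — -3%

In a functional assay on Malme-3M cells (Homo sapiens) for cytotoxicity, read by sulforhodamine B assay, with a stated time of 48 h, tested at 10 uM (on this read-out lower numbers stand for a stronger effect and higher numbers for a weaker effect at the one concentration tested), compound 2 gives the lowest of the three numbers; compound 1 gives a higher number, beyond the scatter, and compound 3 the highest of the set. For the measured compounds named here, the one step between compounds that differ in a single place, a number 42 percentage points higher from compound 2 to compound 3 (beyond the scatter), concerns the aryl group on the carbonyl carbon and does not touch the methoxy-bearing ring, so it does not bear on the change here.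

Compound 4 `COc1ccc(-c2cc(/C=C/C(=O)c3ccc(N)cc3)[nH]n2)cc1OC` differs from compound 2 in one place: hydrogen in place of methoxy on an aromatic carbon. Going by the values given here, compound 1 carries only one methoxy on that ring and sits between compound 2 and compound 3, but it differs from compound 2 in two places, so only its value, not a step, is available. Compound 4 is expected to sit between compound 2 and compound 1 in this assay, at -34% with a range of -55% to -13%, which means an expected step of a number 11 percentage points higher from compound 2 to compound 4 (beyond the scatter), of uncertain size relative to the scatter.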

Compound 4, a percentage reported as activity, at one concentration (the size of the read-out at that concentration, not a potency): 37%
Compound 4: middle estimate off by 71 percentage points, on the low side, and the stated range ends below it.
By their numbers in this assay, from the lowest: compound 2; then compound 1; then compound 3; then compound 4.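

In this assay, for the compounds shown here, this aromatic carbon proves highly sensitive to its substituent: a number 82 percentage points higher from compound 2 to compound 4 (beyond the scatter) with hydrogen in place of methoxy, and compound 4, at 37%, is the only compound of the four with a positive number. Adding a methoxy group to compound 1 also gives a large change, a number 60 percentage points higher from compound 1 to compound 4 (beyond the scatter), so among these three compounds the number does not follow the count of methoxy groups, since compound 4 with its intermediate count stands above both neighbours. No measurement at hand accounts for either step.

The compounds shown leave open whether the low number of compound 2 depends on methoxy itself or would persist with a hydroxyl, an ethoxy group or a fluorine on that aromatic carbon. They also leave open whether the same change would have a similar effect with the 3,4-difluorophenyl group of compound 3 on the carbonyl carbon.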